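Extending the methyl on the core nitrogen of compound 1

The source may hold more compounds than are shown below. What is called first, only, known or untested is meant among the compounds shown, and "the series" means these compounds.

Compound 1, with the structure `Cn1c(-c2ccccc2)nc2c(NC3CCCC3)ncnc21`, is tested in a functional assay on CHO cells for antagonist activity at adenosine receptor A2b (Homo sapiens), read by 33P incorporation, with a stated time of 20 min; on this read-out lower numbers stand for stronger inhibition and higher numbers for weaker inhibition. In this assay, among the measured compounds shown here, compound 1 gives 8510 nM, the second highest of the three numbers measured so far. Its nearest neighbour is compound 3, `Cn1c(-c2ccc(O)cc2)nc2c(NC3CCCC3)ncnc21`, which in this assay gives 17800 nM; the change between them is a 2.1-fold higher number from compound 1 to compound 3 (0.32 log units; beyond the scatter). Further away is compound 2, `Cn1c(-c2cccc(Cl)c2)nc2c(NC3CCCC3)ncnc21`, which in this assay gives 2530 nM; that change is a 3.4-fold lower number from compound 1 to compound 2 (0.53 log units; beyond the scatter). Between the two neighbours the change is a 7.0-fold higher number from compound 2 to compound 3 (0.85 log units; beyond the scatter).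

Compound 4, `CCn1c(-c2ccccc2)nc2c(NC3CCCC3)ncnc21`, differs from compound 1 by methyl in place of hydrogen on a saturated chain carbon bound to an aromatic nitrogen. The three measured steps all alter the phenyl ring attached to the shared core, and none touches the methyl on the core nitrogen, so none of them bears directly on this change. Each of those ring changes moved the number by a modest amount, and a single added carbon on a saturated chain is a smaller alteration than any of them. Compound 4 is therefore expected to show a step of about a 1.1-fold lower number from compound 1 to compound 4 (0.03 log units; within the scatter), that is, no change beyond the usual scatter. The estimate for compound 4 in this assay is 8000 nM, with a range from 3000 nM to 22000 nM.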

Compound 4, inhibition constant: 5790 nM
Estimate against measurement, compound 4: 1.4-fold (0.14 log units) above; the measured number falls inside the stated range.
By their numbers in this assay, from the lowest: compound 2; then compounds 4 and 1 (each within the scatter of the next); then compound 3.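

In this assay, among the compounds shown here, this is the first change that leaves the phenyl ring alone and acts instead on a saturated chain carbon bound to an aromatic nitrogen, and the step is a 1.5-fold lower number from compound 1 to compound 4 (0.17 log units; within the scatter). The three earlier steps, all made on the phenyl ring, each moved the number beyond the scatter, whereas going from methyl to ethyl at this position gives a difference that cannot be told apart from repeat-measurement noise, so this position accepts an ethyl in place of the methyl without a measurable loss or gain. No supporting data are available to account for this result.

A single extension says little about how far the position can be pushed, so the compounds shown leave open whether a longer chain such as propyl or butyl, a benzyl group, or a chain ending in an amine or a carboxylic acid would also leave the number unchanged. They also leave open whether ethyl in this place would give a similar result when combined with the 3-chlorophenyl group of compound 2 or the 4-hydroxyphenyl group of compound 3.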